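A few compounds are considered here, and "the series" means these few. Any claim that something is new, unique, unknown or untested is made for them only; others in the source may bear on it.

Measured compounds:
compound 1 `COc1cc(/C=C/C(=O)c2cccc(-n3cc(-c4ccccc4)[nH]c3=O)c2)ccc1O`, which in a functional assay on SNB-75 cells (Homo sapiens) for inhibition (on this read-out lower numbers stand for stronger inhibition of growth and higher numbers for weaker inhibition of growth), gives 3900 nM
compound 2 `COc1cc(/C=C/C(=O)c2cccc(-n3cc(-c4ccccc4)[nH]c3=O)c2)cc(OC)c1OC`, which in this assay gives 4470 nM

Compound 2 thus gives the higher of the two numbers, but the gap to compound 1 lies within the scatter of this assay, so the two compounds cannot be told apart on these data. Compound 3 `COc1ccc(-c2cn(-c3cccc(C(=O)/C=C/c4cc(OC)c(OC)c(OC)c4)c3)c(=O)[nH]2)cc1` differs from compound 2 by methoxy in place of hydrogen on an aromatic carbon; read one bond further out, the difference is phenyl to 4-methoxyphenyl. Among the measured compounds shown here, no step between measured compounds shows what this change does in this assay, so nothing in the data points to a direction. The step expected from compound 2 to compound 3 is therefore small, a 1.1-fold lower number from compound 2 to compound 3 (0.03 log units; within the scatter), and within the scatter in either direction. On that basis compound 3 is estimated to give 4200 nM in this assay, with a range from 1500 nM to 12000 nM.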

Compound 3, concentration for 50% growth inhibition: 4590 nM
Compound 3: middle estimate off by 1.1-fold (0.04 log units), on the low side, and the stated range covers the measured number.
By their numbers in this assay, from the lowest: compounds 1, 2 and 3 (each within the scatter of the next).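

Among the compounds shown here, the first reading of a change at this position comes from this assay: methoxy in place of hydrogen, on an aromatic carbon para to a large group, gives a 1.0-fold higher number from compound 2 to compound 3 (0.01 log units; within the scatter). That step lies within the scatter, so compound 2 and compound 3 cannot be told apart, and the position takes a methoxy group with no difference that this read-out can resolve. No supporting data bear on this result, so it stays a plain observation on one pair of compounds.

Going by these compounds, whether an amine, a carboxylic acid or a longer chain at this same position would separate from compound 2 remains open. So does whether methoxy at this place would read the same on compound 1, whose other end differs from that of compound 2.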